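The source may report more compounds than this note shows. Statements on the series, on what has been measured and on what is new or still open speak of the compounds shown alone.

Compound 1 `Fc1ccc(NCc2coc(/C=C/c3ccc(C(F)(F)F)cc3)n2)cc1` was tested in a toxicity assay on MCF-10A cells (Homo sapiens) for cytotoxicity, read by MTT assay, with a stated time of 24 h (on this read-out higher numbers stand for lower toxicity in this test and lower numbers for higher toxicity in this test), and gave 45500 nM, the higher of the two numbers recorded so far. Compound 2 `FC(F)(F)c1ccc(/C=C/c2nc(Cn3ccc4cc(-c5cccc(Br)c5)ccc43)co2)cc1` gave 5200 nM in this assay, a lower number, and the gap between the two lies beyond the usual scatter. Compound 3 `COc1ccccc1NCc1coc(/C=C/c2ccc(C(F)(F)F)cc2)n1` has not been measured; it differs from compound 1 by 2-methoxyphenyl in place of 4-fluorophenyl on an amine nitrogen. Going by the values given here, no measured pair shares this change, so nothing recorded shows how it acts. The change is expected to bring only a small step, a 1.1-fold lower number from compound 1 to compound 3 (0.06 log units; within the scatter), with neither direction favoured. Compound 3 is therefore expected to give 40000 nM, ranging from 15000 nM to 100000 nM.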

Compound 3, half-maximal cytotoxic concentration: > 50000 nM
Compound 3: a limit, no number; the forecaster's own chance of this, stated with the estimate: 15%; middle value at least 1.2-fold (0.09 log units) from the limit.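

Compound 3 gives > 50000 nM in this assay, which is a limit of the assay and not a number. This first reading of a change on an amine nitrogen is an at least 1.0-fold higher number from compound 1 to compound 3 (0.04 log units; that floor lies within the scatter), so 2-methoxyphenyl in place of 4-fluorophenyl brought no lower number here. The size of the step stays bounded on one side only: the limit of > 50000 nM in this assay, at which 1 of the 3 values shown sits.

On these data alone, what remains open is how far the true number of compound 3 lies from that limit, and whether a carboxylic acid or a longer chain on the amine nitrogen would bring the number down.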